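The source may hold more compounds than are shown below. What is called first, only, known or untested is meant among the compounds shown, and "the series" means these compounds.

Measured so far in an ADME assay on MDCK-II cells (Canis lupus familiaris) for permeability (a lower number here means that the compound crosses the layer more slowly, a higher number that the compound crosses the layer faster), are three compounds
- compound 1 `O=C(O)c1cncc(CN2CCC[C@H](O[C@H](CO)c3cc(Cl)cc(Cl)c3)[C@@H]2c2ccccc2)c1` gives 14 10^-6 cm/s
- compound 2 `COC(=O)Nn1c(C[C@H]2CCC[C@H](OCc3cc(C(F)(F)F)cc(C(F)(F)F)c3)[C@@H]2c2ccccc2)n[nH]c1=O` gives 15 10^-6 cm/s
- compound 3 `O=C(O)c1ccc(CN2CCC[C@H](O[C@H](CO)c3cc(Cl)cc(Cl)c3)[C@@H]2c2ccccc2)cc1` gives 16 10^-6 cm/s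

Compound 1 cannot be ranked against the other two, since all three values lie within the usual scatter of one another. Compound 2 differs from compound 1 in more than one place, so it offers no clean comparison.

The step followed here leads to compound 4 `O=C(O)c1ccc2c(CN3CCC[C@H](O[C@H](CO)c4cc(Cl)cc(Cl)c4)[C@@H]3c3ccccc3)c[nH]c2c1` and changes one group of compound 1, leaving the rest of the core as it is: 6-carboxy-1H-indol-3-yl in place of 5-carboxypyridin-3-yl on a saturated chain carbon bound to an amine nitrogen in a ring (in words, 6-carboxy-1H-indol-3-yl in place of 5-carboxypyridin-3-yl on a saturated chain carbon bound to an amine nitrogen in a ring).

For the measured compounds named here, one measured step touches this same place, and it is a 1.1-fold higher number from compound 1 to compound 3 (0.06 log units; within the scatter) for a swap from 5-carboxypyridin-3-yl to 4-carboxyphenyl. That single step points in no clear direction. Going by the values given here, no measured compound carries the 6-carboxy-1H-indol-3-yl group, so the range has to stay wide. In this assay no step beyond the scatter is expected. An estimated 1.1-fold lower number from compound 1 to compound 4 (0.03 log units; within the scatter) is what this reasoning leads to. For compound 4 the expected value is 13 10^-6 cm/s with an estimated range from 7 10^-6 cm/s to 22 10^-6 cm/s (an estimate, not a measurement).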

Compound 4, apparent permeability in the MDCK-II assay: 4 10^-6 cm/s
The estimate for compound 4 lay 3.3-fold (0.51 log units) above the measured number; measured number outside the range, below it.
By their numbers in the MDCK-II assay, from the lowest: compound 4; then compounds 1, 2 and 3 (each within the scatter of the next).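

At this place, on a saturated chain carbon bound to an amine nitrogen in a ring, the earlier swap between the two single-ring acid groups gave in the MDCK-II assay a 1.1-fold higher number from compound 1 to compound 3 (0.06 log units; within the scatter) so the position looked tolerant. In the MDCK-II assay the 6-carboxy-1H-indol-3-yl group brings a 3.5-fold lower number from compound 1 to compound 4 (0.54 log units; beyond the scatter) and also a 4.0-fold lower number from compound 3 to compound 4 (0.60 log units; beyond the scatter) as the first clear difference at this place, which shows that the group here can matter for this read-out. In a physicochemical assay for solubility, read by HPLC, with a stated time of 24 h, at pH 7 (a higher number here means a more soluble compound, a lower number a less soluble compound), compound 1 gives 74000 nM and compound 4 gives 128000 nM and the same swap gives a 1.7-fold higher number from compound 1 to compound 4 (0.24 log units; within the scatter) so the two compounds are not told apart on that read-out, and of the two read-outs only the first separates them.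

The group that enters differs in several ways at once, with a five-membered aromatic ring added to a six-membered one and an extra hydrogen-bond donor, so these compounds leave open which of those features goes with the step, and how a tetrazole or a primary amide in place of the carboxylic acid would read. No supporting evidence is available here to explain the step.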